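Dropping One Methoxy Group on Two Different Cores

This account rests on a few compounds, and the source may have more. Where it says the series, first, only, none or still open, it means among the compounds named here.

Of the compounds shown here, three have been tested in a functional assay on IMR-32 cells (Homo sapiens) for cytotoxicity, read by sulforhodamine B assay, with a stated time of 48 h; on this read-out higher numbers stand for weaker inhibition and lower numbers for stronger inhibition. Compound 1, `COc1cc(C2CC(c3ccco3)=NN2C(C)=O)cc(OC)c1OC`, gives 9870 nM in this assay. Compound 2, `COc1ccc(C2CC(c3ccco3)=NN2C(C)=O)cc1OC`, gives 11200 nM in this assay. These two differ in a single place: hydrogen in place of methoxy on an aromatic carbon. The step that this made, a 1.1-fold higher number from compound 1 to compound 2 (0.05 log units; within the scatter), is small. Compound 3, `COc1ccc(C2CC(c3cccc4ccccc34)=NN2C(C)=O)c(OC)c1OC`, gives 1790 nM in this assay and stands lowest of the three, with both other compounds beyond the scatter above it; how its core differs from the core of compound 1 is not broken down here.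

Compound 4, `COc1ccc(C2CC(c3cccc4ccccc34)=NN2C(C)=O)cc1OC`, has not yet been measured in this assay. It differs from compound 3 in one place: hydrogen in place of methoxy on an aromatic carbon. Going by the values given here, this is the same kind of change as the one from compound 1 to compound 2, but the surroundings are not identical: in compound 1 the leaving methoxy is meta to a large group and ortho to a methoxy group, whereas in compound 3 it is ortho to a large group, ortho to a methoxy group and meta to a methoxy group. Because a 1.1-fold higher number from compound 1 to compound 2 (0.05 log units; within the scatter) lay within the scatter, the step from compound 3 to compound 4 is expected to be small as well, a 1.4-fold higher number from compound 3 to compound 4 (0.15 log units; within the scatter). The estimate for compound 4 in this assay is therefore 2500 nM, with a likely range from 1000 nM to 7000 nM.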

Compound 4, half-maximal inhibitory concentration: 1680 nM
Compound 4: middle estimate off by 1.5-fold (0.17 log units), on the high side, within the range that was stated.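

In this assay, putting hydrogen in place of the methoxy group gives a 1.1-fold lower number from compound 3 to compound 4 (0.03 log units; within the scatter), so on this core the change makes no difference that stands out from the usual spread of repeated measurements. Set beside the earlier case, the change behaves alike on both cores, and the two steps cannot be told apart: the same change on two cores in this assay, a 1.1-fold higher number (0.05 log units; within the scatter) from compound 1 to compound 2 and a 1.1-fold lower number (0.03 log units; within the scatter) from compound 3 to compound 4, 1.2-fold (0.08 log units) apart, within the scatter of two such steps. This shows only that losing this one methoxy group left the number within the scatter on two cores, and in two different surroundings on the aromatic ring; two pairs are too few to show that the same would hold on a further core, or that the methoxy groups that remain could be exchanged just as freely.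

The compounds shown only ever replace methoxy with hydrogen, which leaves open what a different group in that place would do, such as a hydroxyl group, a fluorine atom, an amine or a longer chain like butoxy. They also leave open whether the two cores would still agree on a change that gave a step clearly beyond the scatter, since neither step here is large enough to test that.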